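Isopropyl for Hydrogen on the Core: Cytotoxicity Outlook

The source may hold more compounds than are shown below. What is called first, only, known or untested is meant among the compounds shown, and "the series" means these compounds.

Compound 2 `CS(=O)(=O)CCCn1c(Cn2c(=O)[nH]c3ccncc32)cc2cc(Cl)ccc21` carries a hydrogen on an aromatic nitrogen of its core. In an ADME assay on HeLa cells (Homo sapiens) for cytotoxicity, read by ATP content, with a stated time of 3 days (a higher number here means that more compound is tolerated, a lower number that less compound is tolerated), compound 2 reaches only the limit of the assay, > 50000 nM. Compound 1 `CS(=O)(=O)CCCn1c(Cn2c(=O)n(C3CN(S(C)(=O)=O)C3)c3ccncc32)cc2cc(Cl)ccc21` bears a 1-(methylsulfonyl)azetidin-3-yl group on that nitrogen. In this assay compound 1 likewise stops at the limit, > 50000 nM. Compound 3 `CC(C)CCn1c(Cn2c(=O)n(C3CC3)c3ccncc32)cc2cnccc21` carries a cyclopropyl on the corresponding nitrogen of a related core. In this assay compound 3 also sits at the limit, > 50000 nM. The step that the two limits leave unreadable from compound 1 to compound 2 therefore cannot be sized, as both of its ends are limits. Every value shown here sits at the limit of > 50000 nM in this assay, at which 3 of the 3 values shown sit.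

Compound 4 `CC(C)n1c(=O)n(Cc2cc3cc(Cl)ccc3n2CCCS(C)(=O)=O)c2cnccc21` arises from compound 2 through (isopropyl in place of hydrogen on an aromatic nitrogen). Within the data shown here, no measured step gives a readable size for a change of this kind; the only step at the same position, a step that the two limits leave unreadable from compound 1 to compound 2, is unreadable from its two limits, and the substituents of compound 1 and compound 3 on that nitrogen left both at the limit. The expected step of a number no higher from compound 2 to compound 4 (the limit leaves the size open) is accordingly none beyond the scatter, and it is most likely that only a limit will again be reported. Compound 4 is expected to sit at about 50000 nM, with a range from 20000 nM to 100000 nM.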

Compound 4, half-maximal cytotoxic concentration: > 50000 nM
Compound 4: a limit, no number; the forecaster's own chance of this, stated with the estimate: 85%; the middle value sits exactly at the limit.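

In this assay compound 4 gives > 50000 nM, a limit and not a number, so neither its step from compound 1 nor its step from compound 2 can be read: the limit of > 50000 nM in this assay, at which 4 of the 4 values shown sit.

The compounds shown leave open whether any group on that aromatic nitrogen, hydrogen and isopropyl included, changes the tolerated concentration at all.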